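Compound 3: Propyl to Allyl on the Shared Core

The source may hold more compounds than are shown below. What is called first, only, known or untested is meant among the compounds shown, and "the series" means these compounds.

Compound 1 (`Oc1nnc(-c2cccnc2)c2ccccc12`): 10200 nM
Compound 2 (`CCCn1nc(-c2cccnc2)c2ccccc2c1=O`): 3160 nM

In a functional assay (trachea) with Cavia porcellus as the target (a higher number here means a weaker inhibitor, a lower number a stronger inhibitor), compound 2 gives 3160 nM as the lower of the two numbers, while compound 1 gives 10200 nM and that gap lies beyond the usual scatter. Compound 3 (`C=CCn1nc(-c2cccnc2)c2ccccc2c1=O`) has not yet been measured. It differs from compound 2 by one change (vinyl in place of ethyl on a saturated chain carbon bound to an aromatic nitrogen), with vinyl in place of ethyl on a saturated chain carbon bound to an aromatic nitrogen, which also reads as propyl to allyl. For the measured compounds named here, no measured step of this kind is available, so the expectation starts from compound 2 at 3160 nM and foresees no step beyond the scatter in this assay in either direction. The expected step of a 1.1-fold lower number from compound 2 to compound 3 (0.02 log units; within the scatter) stays within the scatter. For compound 3 the estimated value is 3000 nM with an expected range from 1200 nM to 7500 nM as its half-maximal inhibitory concentration.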

Compound 3, half-maximal inhibitory concentration: 2140 nM
Compound 3: the middle estimate sits 1.4-fold (0.15 log units) above what was measured, within the range that was stated.
By their numbers in this assay, from the lowest: compounds 3 and 2 (each within the scatter of the next); then compound 1.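

For the compounds shown here, the step of a 1.5-fold lower number from compound 2 to compound 3 (0.17 log units; within the scatter) in this assay is the first direct reading of a change at this position, on a saturated chain carbon bound to an aromatic nitrogen. It shows that, at this position on the shared core, this assay does not separate propyl from allyl: exchanging ethyl for vinyl keeps the count of heavy atoms and adds a double bond outside the aromatic rings, and the two values remain within the scatter of each other. Nothing available accounts for this outcome or links it to any property of either group.

As far as these compounds go, whether a longer chain, a benzyl group or a chain ending in an amine or a carboxylic acid at this position would shift the number beyond the scatter stays open. From the compounds shown here alone, it also remains open whether vinyl in place of ethyl would behave the same way on any other core.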